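The source may hold more compounds than are shown below. What is called first, only, known or untested is meant among the compounds shown, and "the series" means these compounds.

Measured so far in a functional assay on MCF7 cells (Homo sapiens) for cytotoxicity, read by MTT assay, with a stated time of 72 h; a lower number here means a stronger inhibitor, a higher number a weaker inhibitor: compound 1 `COc1cccc(/C=C2\CCC/C(=C\c3ccc(Cl)cc3Cl)C2=O)c1OC`, compound 2 `COc1cccc(/C=C2\CCC/C(=C\c3ccc(Cl)c(Cl)c3)C2=O)c1OC`, compound 3 `COc1ccc(/C=C2\CCC/C(=C\c3ccc(Cl)cc3Cl)C2=O)cc1OC`.

Compound 1 is reported only at a limit of this assay, > 20000 nM. Compound 2 gives 9000 nM. Compound 3 gives 16200 nM. The step of an at least 2.2-fold lower number from compound 1 to compound 2 (0.34 log units; beyond the scatter) follows the change (3,4-dichlorophenyl in place of 2,4-dichlorophenyl on a double-bonded chain carbon bound to a double-bonded ring carbon); its true size is open-ended because of the limit of > 20000 nM in this assay, at which 1 of the 3 values shown sits. Compound 2 and compound 3 lie within the scatter of one another. The difference between the core of compound 1 and the core of compound 3 is not broken down here. Compound 4 `COc1ccc(/C=C2\CCC/C(=C\c3ccc(Cl)c(Cl)c3)C2=O)cc1OC`, not yet measured, carries the same change as before, (3,4-dichlorophenyl in place of 2,4-dichlorophenyl on a double-bonded chain carbon bound to a double-bonded ring carbon), at the same place. A step of a 2.5-fold lower number from compound 3 to compound 4 (0.40 log units; beyond the scatter) is expected beside the earlier one, resting on compound 3 at 16200 nM and on the direction seen from compound 1 to compound 2. Compound 4 is estimated at 6500 nM, between 2500 nM and 16000 nM.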

Compound 4, half-maximal inhibitory concentration: 4400 nM
Beside the measured number, compound 4's estimate is 1.5-fold (0.17 log units) above it; low and high end bracket the measured number.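

In this assay, 3,4-dichlorophenyl in place of 2,4-dichlorophenyl gives a 3.7-fold lower number from compound 3 to compound 4 (0.57 log units; beyond the scatter) on this second core, so the change lowers the number in the same direction on both cores shown. Whether the step is the same size on the two cores cannot be said, as the two steps show when set together: the same change on two cores in this assay, an at least 2.2-fold lower number (0.34 log units; beyond the scatter) from compound 1 to compound 2 and a 3.7-fold lower number (0.57 log units; beyond the scatter) from compound 3 to compound 4; the limit leaves it open whether they differ. Two cores are too few to make a general rule, and these numbers do not explain why the change lowers the number.

As far as these compounds go, it remains open whether the change would carry over to a core bearing an amine or a carboxylic acid instead of the methoxy groups. Also open, from the compounds shown here alone, is how a phenyl ring bearing nitrile groups instead of chlorines would compare.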